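Methyl for chlorophenyl on the carbonyl carbon

The source may hold more compounds than are shown below. What is called first, only, known or untested is meant among the compounds shown, and "the series" means these compounds.

Measured compounds:
Compound 1 `CCCC(=O)N1c2ccccc2CCC1C(=O)Nc1ccccc1C(F)(F)F` — in a functional assay on HCT-15 cells (Homo sapiens) for cytotoxicity, read by sulforhodamine B assay, with a stated time of 72 h (a lower number here means a stronger inhibitor of growth, a higher number a weaker inhibitor of growth), compound 1 gives > 70000 nM, which is a limit of the assay.
Compound 2 `O=C(Nc1ccccc1C(F)(F)F)C1CCc2ccccc2N1C(=O)c1cccc(Cl)c1` — in this assay compound 2 gives 797 nM.
Compound 3 `O=C(Nc1ccccc1C(F)(F)F)C1CCc2ccccc2N1C(=O)c1ccc(Cl)cc1` — in this assay compound 3 gives 839 nM.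

Compound 3 holds the higher of the two numbers measured, with compound 2 beside it: a 1.1-fold higher number from compound 2 to compound 3 (0.02 log units; within the scatter), which lies within the scatter. The value of compound 1 is a limit (the limit of > 70000 nM in this assay, at which 1 of the 3 values shown sits). From compound 1 the two measured steps were large: an at least 87-fold lower number from compound 1 to compound 2 (1.94 log units; beyond the scatter) and an at least 83-fold lower number from compound 1 to compound 3 (1.92 log units; beyond the scatter). Compound 4 `CC(=O)N1c2ccccc2CCC1C(=O)Nc1ccccc1C(F)(F)F` differs from compound 3 by methyl in place of 4-chlorophenyl on a carbonyl carbon. This change puts an alkyl group back on the carbonyl carbon, as in compound 1, so the two large steps from compound 1 bear on it in reverse. Compound 4 is therefore expected to show a large upward step in this assay, an 83-fold higher number from compound 3 to compound 4 (1.92 log units; beyond the scatter), most likely back to the limit of the assay. The estimate for compound 4 is 70000 nM, expected to lie between 20000 nM and 200000 nM.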

Compound 4, concentration for 50% growth inhibition: > 80000 nM
Compound 4 gave a limit, no number; the forecaster's own chance of this, stated with the estimate: 70%; at least 1.1-fold (0.05 log units) between middle value and limit.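

Methyl, like propyl before it, leaves the compound far weaker than the chlorophenyl amides in this assay, so the large gap no longer rests on a single alkyl group: there is an at least 95-fold higher number from compound 3 to compound 4 (1.97 log units; beyond the scatter) and an at least 100-fold higher number from compound 2 to compound 4 (2.00 log units; beyond the scatter), both large. The value of compound 4 is a limit, not a number: the limit of > 80000 nM in this assay, at which 1 of the 4 values shown sits. The step between compound 1 and compound 4 cannot be read, so nothing can be said about how methyl and propyl compare.

On these data alone, what a plain phenyl, a cyclohexyl or a pyridyl group on this carbonyl carbon would give remains open, and with it whether the aromatic ring or the chlorine carries the difference. Also open, as far as these compounds go, is what a longer chain or an amine at this place would give in this assay.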